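The source may report more compounds than this note shows. Statements on the series, on what has been measured and on what is new or still open speak of the compounds shown alone.

Measured so far:
- Compound 1, `COc1cc2ncnc(Nc3cc(-c4ccccc4)[nH]n3)c2cc1OC`, gives < 100000 nM in a functional assay on ZR-75-1 cells (Homo sapiens) for cytotoxicity, read by MTT assay; a higher number here means a weaker inhibitor, a lower number a stronger inhibitor.
- Compound 2, `COc1cc2ncnc(Nc3cc(-c4ccc(F)cc4)[nH]n3)c2cc1OC`, gives < 100000 nM in this assay.

The value of compound 2 in this assay is a limit of the assay, not a number. The same holds for compound 1, whose value is also a limit. This is summed up by the limit of < 100000 nM in this assay, at which 2 of the 2 values shown sit, so neither compound has a number of its own. Among the compounds with values here, the only measured step, a step that the two limits leave unreadable from compound 1 to compound 2, is therefore unreadable in size and direction.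

Compound 3, `COc1ccc(-c2cc(Nc3ncnc4cc(OC)c(OC)cc34)n[nH]2)cc1`, differs from compound 2 by methoxy in place of fluoro on an aromatic carbon. No measured step bears on this change in a readable way, because the one step shown, a step that the two limits leave unreadable from compound 1 to compound 2, sits between two limits. What compound 2 offers is a limit only, and compound 3 is expected to stand near the same limit, with no step beyond the scatter being predictable from the data.

Compound 3 is therefore estimated at 60000 nM in this assay, within 8000 nM to 100000 nM. The step that the limit leaves unreadable from compound 2 to compound 3 is the expectation, with a real number rather than a limit being the less likely outcome.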

Compound 3, half-maximal inhibitory concentration: < 100000 nM
Compound 3: a limit, no number; the forecaster's own chance of this, stated with the estimate: 70%; the middle value is on the limit's open side.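

In this assay compound 3 gives < 100000 nM as a limit of the assay, not a number. Within the data shown here, no step between compound 1, compound 2 and compound 3 can be read, in size or direction, because all three rest on the same limit: the limit of < 100000 nM in this assay, at which 3 of the 3 values shown sit. Still open, going by these compounds, is how strongly each compound acts on these cells, and whether hydrogen, fluoro and methoxy at this one place differ at all.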